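Replacing a nitrile with a thioamide on a nucleoside core

This account rests on a few compounds, and the source may have more. Where it says the series, first, only, none or still open, it means among the compounds named here.

Measured compounds:
Compound 1: `N#Cc1cn([C@H]2C[C@H](O)[C@@H](CO)O2)c2ncnc(N)c12` gives 25000 nM
Compound 2: `N#Cc1cn(C2CCC(CO)O2)c2ncnc(N)c12` gives 88000 nM

Of the compounds shown here, two have been measured in a functional assay on KB cells (Homo sapiens) for inhibition (on this read-out higher numbers stand for weaker inhibition and lower numbers for stronger inhibition), and both are weak inhibitors. Compound 1 gives 25000 nM in this assay, while compound 2 gives 88000 nM. Compound 2 therefore stands at the highest number of the two, which means the weakest inhibition; the gap to compound 1 is beyond the usual scatter of repeated measurements, so the two values can be told apart.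

The next compound, compound 3, has the structure `NC(=S)c1cn(C2CCC(CO)O2)c2ncnc(N)c12`. It keeps the whole of compound 2 except at one spot: a group of 3 heavy atoms (1 carbon, 1 nitrogen, 1 sulfur; no ring) in place of a group of 2 heavy atoms (1 carbon, 1 nitrogen; no ring), on an aromatic carbon. The change is small in size but exchanges a nitrile for a thioamide, which brings a hydrogen-bond donor to a part of the core that had none.

For the measured compounds named here, no measured pair shows what this exchange does on this core, so the expectation for compound 3 rests only on the weak starting point of compound 2. The step from compound 2 to compound 3 in this assay is estimated as a 1.8-fold lower number from compound 2 to compound 3 (0.25 log units; within the scatter), a modest move toward stronger inhibition that may not clear the scatter. Compound 3 is accordingly expected to give about 50000 nM, within a range from 10000 nM to 250000 nM.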

Compound 3, half-maximal inhibitory concentration: 11000 nM
Compound 3: the middle estimate sits 4.5-fold (0.66 log units) above what was measured; the measured number falls inside the stated range.
By their numbers in this assay, from the lowest: compound 3; then compound 1; then compound 2.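

This carbon on the five-membered aromatic ring responds to a change of group: in this assay, exchanging the cyano group for the thioamide gives an 8.0-fold lower number from compound 2 to compound 3 (0.90 log units; beyond the scatter), a step toward stronger inhibition. Compound 1 and compound 2 differ elsewhere, so they showed nothing about this carbon. The new step therefore shows that this position can tune activity on this core, and that a small exchange, from a group of 2 heavy atoms to a group of 3, is enough to move the value beyond the scatter. The entering group brings a hydrogen-bond donor and a sulfur atom, but no measurement here ties the step to either feature.

Still open, on these data alone, is how a plain amide, with a carbonyl in place of the thiocarbonyl, or a carboxylic acid would behave at this carbon. Also open, as far as these compounds go, is whether the thioamide would give a similar step on the core of compound 1, which carries a hydroxyl group on its ring.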